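This account rests on a few compounds, and the source may have more. Where it says the series, first, only, none or still open, it means among the compounds named here.

Compound 1, `COc1ccc(N(CC(=O)NCCCSc2ccccc2)C(=O)CNC(=O)OC(C)(C)C)cc1`, gives 3.12 in a physicochemical assay for lipophilicity, read by HPLC, measured as octanol-water partition; a higher number here means a more lipophilic compound, a lower number a more polar compound.
Compound 2, `COc1ccc(N(CC(=O)NCCC[Se]c2ccccc2)C(=O)C#Cc2ccccc2)cc1`, gives 2.6 in this assay.

Compound 2 holds the lower of the two numbers; compound 1 lies higher, a gap that falls beyond the usual scatter. Compound 3, `COc1ccc(N(CC(=O)NCCCSc2ccccc2)C(=O)C#Cc2ccccc2)cc1`, has not yet been measured and differs from compound 2 in one place: a group of 7 heavy atoms (6 carbon, 1 sulfur; one six-membered aromatic ring of carbon only) in place of a group of 7 heavy atoms (6 carbon, 1 selenium; one six-membered aromatic ring of carbon only), on a saturated chain carbon, three bonds along the chain from an amide-type nitrogen. The two compounds otherwise share the same core. Going by the values given here, no measured pair in this set shows the effect of such an exchange, so there is no direct precedent to lean on. The step from compound 2 to compound 3 in this assay is expected to be small, most likely a slight drop that may not exceed the scatter, as a number 0.15 log units lower from compound 2 to compound 3 (within the scatter). Compound 3 is therefore estimated at 2.45, with a plausible range from 2.1 to 2.8.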

Compound 3, partition coefficient: 3.4
For compound 3 the middle estimate is 0.95 log units below the measured one; measured number outside the range, above it.
By their numbers in this assay, from the lowest: compound 2; then compounds 1 and 3 (each within the scatter of the next).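

In this assay, the exchange of the selenium-bearing group for phenylsulfanyl, on a saturated chain carbon, three bonds along the chain from an amide-type nitrogen, gives a number 0.80 log units higher from compound 2 to compound 3 (beyond the scatter), so this position is sensitive to a change of that single atom. With phenylsulfanyl held in place, 2-phenylethynyl in place of ((tert-butoxycarbonyl)amino)methyl on a carbonyl carbon gives a number 0.28 log units higher from compound 1 to compound 3 (within the scatter), which shows that these two quite different groups can be exchanged there without a step beyond the scatter. Nothing available explains the size of either step.

The compounds shown leave open whether the exchange of selenium for sulfur gives a similar step when ((tert-butoxycarbonyl)amino)methyl sits on the carbonyl carbon. They also leave open how an amine or a carboxylic acid in place of phenylsulfanyl would read in this assay.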